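Removing a Methyl from an Oxadiazole Ring

The source may report more compounds than this note shows. Statements on the series, on what has been measured and on what is new or still open speak of the compounds shown alone.

Three compounds have been measured in a functional assay for antagonist activity at transient receptor potential cation channel subfamily V member 1 (Rattus norvegicus); a lower number here means a stronger inhibitor, a higher number a weaker inhibitor:
compound 1, `Cc1cccnc1-c1ccc(C(=O)Nc2ccc(C(C)(C)C)cc2)cc1`, gives 9 nM
compound 2, `CC(C)(C)c1ccc(NC(=O)c2ccc(-c3ccccn3)cc2)cc1`, gives 8 nM
compound 3, `Cc1nnc(-c2cccnc2-c2ccc(C(=O)Nc3ccc(C(C)(C)C)cc3)cc2)o1`, gives 34 nM

Compound 4, `CC(C)(C)c1ccc(NC(=O)c2ccc(-c3ncccc3-c3nnco3)cc2)cc1`, has not yet been measured. It differs from compound 3 by hydrogen in place of methyl on an aromatic carbon. The same kind of change has already been made once among the measured compounds: compound 2 differs from compound 1 by hydrogen in place of methyl on an aromatic carbon, and that step was a 1.1-fold lower number from compound 1 to compound 2 (0.05 log units; within the scatter). The two places are not the same, though. In compound 1 the methyl sits on a six-membered aromatic ring with 1 nitrogen, ortho to a large group and two atoms from the ring nitrogen; in compound 3 it sits on a five-membered aromatic ring with 2 nitrogen and 1 oxygen, next to the ring nitrogen and next to the ring oxygen. The two cores differ as well: compound 3 differs from compound 1 by 5-methyl-1,3,4-oxadiazol-2-yl in place of methyl on an aromatic carbon, and that step was a 3.8-fold higher number from compound 1 to compound 3 (0.58 log units; beyond the scatter); likewise the step was a 4.3-fold higher number from compound 2 to compound 3 (0.63 log units; beyond the scatter).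

For the measured compounds named here, with only one earlier example, on a different ring, the expectation for compound 4 rests on little. Because the earlier step of a 1.1-fold lower number from compound 1 to compound 2 (0.05 log units; within the scatter) stayed within the scatter, a small step is expected here as well. For compound 4 the expected step is a 1.1-fold lower number from compound 3 to compound 4 (0.03 log units; within the scatter). Compound 4 is therefore estimated at 32 nM in this assay, with a range from 12 nM to 90 nM.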

Compound 4, half-maximal inhibitory concentration: 59 nM
Estimate against measurement, compound 4: 1.8-fold (0.27 log units) below; low and high end bracket the measured number.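

In this assay, hydrogen in place of methyl on the 1,3,4-oxadiazol-2-yl ring gives a 1.7-fold higher number from compound 3 to compound 4 (0.24 log units; within the scatter), and this step can be set beside the same swap on the pyridine-free wording of the earlier pair: the same change on two cores in this assay, a 1.1-fold lower number (0.05 log units; within the scatter) from compound 1 to compound 2 and a 1.7-fold higher number (0.24 log units; within the scatter) from compound 3 to compound 4, 2.0-fold (0.29 log units) apart, within the scatter of two such steps. So, in this assay, the change carried from one core to the other without a step beyond the scatter on either, although two pairs, with the methyl on a different ring in each, are too few to make a rule for the series, and they do not explain why the steps are small. The steps that do go beyond the scatter come from adding the ring itself, with a 7.4-fold higher number from compound 2 to compound 4 (0.87 log units; beyond the scatter) and a 6.6-fold higher number from compound 1 to compound 4 (0.82 log units; beyond the scatter), so in these compounds the 1,3,4-oxadiazol-2-yl group matters more to the number than the methyl on it does.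

On these data alone, it stays open whether a larger group on that same ring carbon, such as an ethyl or an amine, would also leave the number within the scatter of compound 4. As far as these compounds go, it is also open whether a nitrile or a carboxylic acid in place of the whole 1,3,4-oxadiazol-2-yl group would give a step as large as those from compound 1 and compound 2.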